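The source may hold more compounds than are shown below. What is called first, only, known or untested is meant among the compounds shown, and "the series" means these compounds.

Measured compounds in the series:

compound 1, `CC(c1ccc(-c2ccccc2)c(F)c1)c1n[nH]c(=S)n1N`: "not active" (no number reported)
compound 2, `COc1ccc(C2=Nn3c(nnc3C(C)c3ccc(-c4ccccc4)c(F)c3)SC2)cc1`: 5800 nM
compound 3, `CC(C)Cc1ccc(C(C)c2nnc3n2N=C(c2ccc(Br)cc2)CS3)cc1`: 8900 nM

The read-out throughout is a functional assay on Mahlavu cells (Homo sapiens) for inhibition, read by sulforhodamine B assay, with a stated time of 72 h; a lower number here means a stronger inhibitor, a higher number a weaker inhibitor. Compound 1 carries no number in this assay, only the report that it showed no activity, so it gives no anchor for comparison. Among the compounds with values here, compound 2 and compound 3 are the only compounds with numbers; the gap between them lies within the usual scatter of repeated measurements, so neither stands apart from the other. Within the data shown here, compound 2 is thus the reference only in the sense that it carries one of two usable numbers, and no single-point steps between measured compounds are available.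

The next compound, compound 4, `CC(c1ccc(-c2ccccc2)c(F)c1)c1nnc2n1N=C(c1ccc([N+](=O)[O-])cc1)CS2`, is not yet measured. It differs from compound 2 in one place: nitro in place of methoxy on an aromatic carbon. Among the measured compounds shown here, no measured pair shows this exchange, so there is nothing to size the step from. The expectation is a step of no more than the scatter in either direction, and compound 4 is estimated at 5000 nM, with a range from 2000 nM to 15000 nM, which amounts to an expected step of a 1.2-fold lower number from compound 2 to compound 4 (0.06 log units; within the scatter).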

Compound 4, half-maximal inhibitory concentration: 9400 nM
The estimate for compound 4 lay 1.9-fold (0.27 log units) below the measured number; measured number inside the range.
By their numbers in this assay, from the lowest: compounds 2, 3 and 4 (each within the scatter of the next).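

In this assay, within the data shown here, the exchange of methoxy for nitro on an aromatic carbon, para to a large group, gives a 1.6-fold higher number from compound 2 to compound 4 (0.21 log units; within the scatter) and so provides the first single-place comparison. At this position, 4-methoxyphenyl and 4-nitrophenyl cannot be told apart in this read-out, although the entering group differs from the leaving one in heavy atoms, hydrogen-bond acceptors and an added double bond outside aromatic rings. Nothing measured on these compounds or groups offers an explanation for this result.

The compounds shown leave open whether any group at this position can move the number beyond the scatter, for example an amine, a carboxylic acid or a longer alkoxy chain in place of methoxy. Among these compounds, it also remains open whether the exchange from 4-methoxyphenyl to 4-nitrophenyl would read the same with the other side group of the core changed to the one carried by compound 3.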